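The compounds below may be only part of what the source reports. "The series", "measured", "known", "first", "only" and "open" are said of these compounds alone.

The series rests on a shared core carrying a cyclohexyl-bearing bicyclic group; compound 1 `Brc1cn2ccnc2c(-c2ccc3ncn(C4CCCCC4)c3c2)n1` has a bromo on an aromatic carbon of that core, and compound 2 `c1cn2cc(-c3ccsc3)nc(-c3ccc4ncn(C5CCCCC5)c4c3)c2n1` carries thiophen-3-yl at the same place. In a functional assay on MDA-MB-231 cells (Homo sapiens) for inhibition, read by sulforhodamine B assay, with a stated time of 48 h, tested at 10 uM (on this read-out lower numbers stand for less inhibition and higher numbers for more inhibition at the one concentration tested (going by the name of the read-out)), compound 1 gives 24.2%, while compound 2 gives 1.35%. Among the compounds with values here, of the two numbers measured, compound 2 stands lowest, and the only step measured, a number 22.9 percentage points lower from compound 1 to compound 2 (beyond the scatter), went downward beyond the scatter.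

Compound 3 `Clc1ccc(-c2cn3ccnc3c(-c3ccc4ncn(C5CCCCC5)c4c3)n2)cc1` differs from compound 2 by 4-chlorophenyl in place of thiophen-3-yl on an aromatic carbon. Within the data shown here, no measured step exchanges one aryl group for another, so the one step available bears only indirectly: it shows that a change at this position can shift this assay by a modest amount, but it does not say which way a chlorophenyl would move it. With a substituent of similar kind at the same position, the expectation for compound 3 is a small rise that may not exceed the scatter, that is a number 6.7 percentage points higher from compound 2 to compound 3 (within the scatter). Compound 3 is therefore expected to give 8% in this assay, within a range of -5% to 30%.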

Compound 3, a percentage reported as inhibition, at one concentration (the size of the read-out at that concentration, not a potency): 15.3%
Estimate against measurement, compound 3: 7.3 percentage points below, and the stated range covers the measured number.
By their numbers in this assay, from the lowest: compound 2; then compounds 3 and 1 (each within the scatter of the next).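

In this assay the exchange of one aryl group for another at this position is enough to move the read-out, with a number 14 percentage points higher from compound 2 to compound 3 (beyond the scatter) as the step, so the fall seen on replacing bromo with thiophen-3-yl does not extend to every aryl group. The 4-chlorophenyl compound is not separated from the bromo compound, the step being a number 8.9 percentage points lower from compound 1 to compound 3 (within the scatter) in this case, which shows that a larger group at this aromatic carbon need not change the number beyond the scatter. Among the three groups shown, only thiophen-3-yl is set apart from both others by steps beyond the scatter, and nothing available explains why the two aryl groups differ.

The compounds shown leave open whether the difference between the two aryl groups follows from the chlorine, the sulfur or the ring size, which an unsubstituted phenyl or a 3-chlorophenyl group at the same place would help to separate. They also leave open how an amine such as morpholine or a carboxylic acid would read at this position, and whether the cyclohexyl group plays any part in these numbers.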